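The source may hold more compounds than are shown below. What is called first, only, known or untested is meant among the compounds shown, and "the series" means these compounds.

Of the compounds shown here, three built on the same acylguanidine core have been tested in a functional assay for inhibition of sodium/hydrogen exchanger (Oryctolagus cuniculus); on this read-out lower numbers stand for stronger inhibition and higher numbers for weaker inhibition. Compound 1 `CS(=O)(=O)c1cc(C(=O)N=C(N)N)c(Cl)cc1Cl` gives 140 nM. Among the compounds with values here, compound 2 `COc1cc(Cl)c(C(=O)N=C(N)N)cc1S(C)(=O)=O` gives 40 nM, and the single change between them, methoxy in place of chloro on an aromatic carbon, produced a 3.5-fold lower number from compound 1 to compound 2 (0.54 log units; beyond the scatter). Compound 3 `Cc1cc(-n2ccnc2)c(S(C)(=O)=O)cc1C(=O)N=C(N)N` gives 23 nM, the lowest of the three numbers; its gap to compound 2 lies within the usual scatter, while its gap to compound 1 lies beyond it.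

The next compound, compound 4 `CS(=O)(=O)c1cc(C(=O)N=C(N)N)c(Cl)cc1-n1ccnc1`, differs from compound 3 in one place: chloro in place of methyl on an aromatic carbon. Within the data shown here, no measured pair shows this particular exchange, and the one recorded step, from compound 1 to compound 2, concerns a different position and a different group, so it offers no direct guidance. What can be said is that compounds 1 and 2, which both carry chloro at the corresponding position, span a range that brackets the neighbourhood of compound 3. The expectation is therefore a step of no clear direction, a 1.3-fold higher number from compound 3 to compound 4 (0.12 log units; within the scatter), with a wide band of uncertainty. Compound 4 is estimated at 30 nM in this assay, likely falling between 10 nM and 90 nM.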

Compound 4, half-maximal inhibitory concentration: 130 nM
The estimate for compound 4 lay 4.3-fold (0.64 log units) below the measured number; the measured number lies above the stated range.
By their numbers in this assay, from the lowest: compounds 3 and 2 (each within the scatter of the next); then compounds 4 and 1 (each within the scatter of the next).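

Swapping one heavy atom at this position matters: with the 1H-imidazol-1-yl group kept in place, this assay shows a 5.7-fold higher number from compound 3 to compound 4 (0.75 log units; beyond the scatter), so the place para to the methylsulfonyl group responds to chloro in place of methyl. The new compound also gives the first view of the other varied position while chloro stays fixed, with a 3.3-fold higher number from compound 2 to compound 4 (0.51 log units; beyond the scatter) for 1H-imidazol-1-yl in place of methoxy and a 1.1-fold lower number from compound 1 to compound 4 (0.03 log units; within the scatter) for 1H-imidazol-1-yl in place of chloro, so on this background methoxy stands apart while the last pair cannot be told apart. The 1H-imidazol-1-yl group therefore does not bring the low number of compound 3 on its own, and nothing shown here speaks to the reason for these steps.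

As far as these compounds go, the methyl and chloro exchange rests on a single pair, so it remains open whether the same step would appear with methoxy instead of the 1H-imidazol-1-yl group. From the compounds shown here alone, it also remains open how an ethyl group or an amine at this position would compare with methyl in compound 3, and whether a longer chain would be tolerated there.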